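Removing a Methyl From a Second Core

The source may report more compounds than this note shows. Statements on the series, on what has been measured and on what is new or still open speak of the compounds shown alone.

Four compounds are compared in an assay on membranes from brain for binding affinity to Fatty-acid amide hydrolase 1 (Mus musculus), read by fluorescence, with stated times of 1 h and 30 min; on this read-out lower numbers stand for stronger inhibition and higher numbers for weaker inhibition. Among the compounds with values here, compound 1 `Cc1cnn(C(=O)NCc2ccc(OC(c3ccccc3)c3ccccc3)cc2)c1` is the first. In this assay compound 1 gives only a limit, > 100000 nM. Compound 2 `O=C(NCc1ccc(OC(c2ccccc2)c2ccccc2)cc1)n1cccn1` differs from compound 1 by hydrogen in place of methyl on an aromatic carbon. For compound 2 this assay likewise reports only a limit, > 100000 nM. With both values at a limit, the step that the two limits leave unreadable from compound 1 to compound 2 cannot be read; both compounds sit at the limit of > 100000 nM in this assay, at which 3 of the 3 values shown sit.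

Compound 3 `Cc1cnn(C(=O)N2CCN(C(c3ccc4ccccc4c3)c3ccc4ccccc4c3)CC2)c1` is built on a different core; the difference between the two cores is not broken down here. Compound 3 also reaches only a limit in this assay, > 100000 nM. Compound 4 `O=C(N1CCN(C(c2ccc3ccccc3c2)c2ccc3ccccc3c2)CC1)n1cccn1` has not yet been measured; it differs from compound 3 by hydrogen in place of methyl on an aromatic carbon, the same change as that from compound 1 to compound 2, made at the same place on the ring.

Within the data shown here, since all three measured compounds sit at the limit of > 100000 nM in this assay, at which 3 of the 3 values shown sit, and the one measured instance of this change left nothing readable, there is no ground to expect compound 4 to move. Compound 4 is therefore expected to give about 150000 nM in this assay, most likely reported as a limit again, somewhere within 50000 nM to 500000 nM. That estimate means an expected step that the limit leaves unreadable from compound 3 to compound 4. It rests on compound 3, which gave only a limit, > 100000 nM.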

Compound 4, half-maximal inhibitory concentration: > 100000 nM
Compound 4: no number, only a limit (the forecaster's own chance of this, stated with the estimate: 90%); the middle value lies beyond the limit too.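

In this assay compound 4 gives > 100000 nM, again a limit and not a number. No step can be read from compound 3 to compound 4, and all four compounds now stand at the same limit: the limit of > 100000 nM in this assay, at which 4 of the 4 values shown sit.

The compounds shown leave open whether the change from 4-methyl-1H-pyrazol-1-yl to 1H-pyrazol-1-yl alters inhibition on either core, and how the two cores compare.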